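Aryl urea swap on the shared core

The source may hold more compounds than are shown below. What is called first, only, known or untested is meant among the compounds shown, and "the series" means these compounds.

compound 1 `O=C(Nc1cccc(C(F)(F)F)c1)Nc1nnc(Sc2ncnc3scc(-c4ccncc4)c23)s1` 22400 nM
compound 2 `O=C(Nc1ccc(Cl)cc1)Nc1nnc(Sc2ncnc3scc(-c4ccncc4)c23)s1` 11600 nM

In a functional assay on HUVEC cells (Homo sapiens) for antiproliferative activity, read by MTT assay, with a stated time of 48 h (a higher number here means a weaker inhibitor, a lower number a stronger inhibitor), compound 1 gives 22400 nM and compound 2 gives 11600 nM. Compound 2 sits within the scatter of compound 1: a 1.9-fold lower number from compound 1 to compound 2 (0.29 log units; within the scatter).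

Compound 3 `COc1cccc(NC(=O)Nc2nnc(Sc3ncnc4scc(-c5ccncc5)c34)s2)c1` is not yet measured. Relative to compound 2 it carries 3-methoxyphenyl in place of 4-chlorophenyl on an amide-type nitrogen. Among the measured compounds shown here, the only measured step, a 1.9-fold lower number from compound 1 to compound 2 (0.29 log units; within the scatter), also exchanges the aryl group on the amide-type nitrogen and stayed within the scatter; no measured compound carries a 3-methoxyphenyl. For compound 3 no step beyond the scatter is therefore expected: a 1.3-fold higher number from compound 2 to compound 3 (0.11 log units; within the scatter). Compound 3 is estimated at 15000 nM, with a range from 5000 nM to 45000 nM.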

Compound 3, half-maximal inhibitory concentration: 67700 nM
For compound 3 the middle estimate is 4.5-fold (0.65 log units) below the measured one; measured number above the stated range.
By their numbers in this assay, from the lowest: compounds 2 and 1 (each within the scatter of the next); then compound 3.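

In this assay the aryl group on the amide-type nitrogen can move the number beyond the scatter, which the exchange between compound 1 and compound 2 did not show. The 3-methoxyphenyl group reads weaker against both earlier groups, with a 5.8-fold higher number from compound 2 to compound 3 (0.77 log units; beyond the scatter) and with a 3.0-fold higher number from compound 1 to compound 3 (0.48 log units; beyond the scatter) for methoxy in place of trifluoromethyl on an aromatic carbon. Nothing at hand gives a reason for this loss.

Open, on these data alone, is how an unsubstituted phenyl, or an aryl group carrying an amine or a carboxylic acid, would read here. Also open, as far as these compounds go, is whether methoxy elsewhere on the ring gives the same loss.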